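Permeability notes on a shared-core series

A few compounds are considered here, and "the series" means these few. Any claim that something is new, unique, unknown or untested is made for them only; others in the source may bear on it.

Compound 1 `CNC(=O)c1cc(Oc2ccc3nc(Nc4ccccc4)ncc3c2)ccn1`, compound 2 `CNC(=O)c1cc(Oc2ccc3nc(Nc4cccc(C(F)(F)F)c4)ncc3c2)ccn1` and compound 3 `CNC(=O)c1cc(Oc2ccc3nc(Nc4cccc(C(C)C)c4)ncc3c2)ccn1` share one core and differ only in the phenyl group on a nitrogen on an aromatic ring. In an ADME assay on Caco-2 cells (Homo sapiens) for permeability, in the apical to basolateral direction (on this read-out lower numbers stand for lower permeability and higher numbers for higher permeability), compound 1 gives < 1 10^-6 cm/s, a limit of the assay and not a number. In this assay compound 2 gives < 1 10^-6 cm/s, again a limit. In this assay compound 3 gives < 1 10^-6 cm/s, also a limit. The steps a step that the two limits leave unreadable from compound 1 to compound 2, a step that the two limits leave unreadable from compound 1 to compound 3 and a step that the two limits leave unreadable from compound 2 to compound 3 therefore cannot be sized, all three values sitting at the limit of < 1 10^-6 cm/s in this assay, at which 3 of the 3 values shown sit. Compound 4 `CNC(=O)c1cc(Oc2ccc3nc(Nc4ccc(OC(F)(F)F)cc4)ncc3c2)ccn1` carries 4-(trifluoromethoxy)phenyl in place of 3-isopropylphenyl on a nitrogen on an aromatic ring. Among the compounds with values here, no measured step bears readably on this change. Compound 4 is expected to stay near the same limit, with a step that the limit leaves unreadable from compound 3 to compound 4 expected to be small. For compound 4 in this assay the estimate is 0.7 10^-6 cm/s, within 0.2 10^-6 cm/s to 2.5 10^-6 cm/s.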

Compound 4, apparent permeability: < 1 10^-6 cm/s
Compound 4 ended at the assay's limit; the forecaster's own chance of this, stated with the estimate: 75%; the middle value is on the limit's open side.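

Compound 4 sits with compound 1, compound 2 and compound 3 at the assay's limit, so no step among these compounds can be read: the limit of < 1 10^-6 cm/s in this assay, at which 4 of the 4 values shown sit. The compounds shown leave open how these phenyl groups differ in this assay.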